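This account rests on a few compounds, and the source may have more. Where it says the series, first, only, none or still open, it means among the compounds named here.

Measured so far, in an assay on HepG2 cells for agonist activity at nuclear receptor subfamily 1 group I member 3 (Homo sapiens), read by a luciferase reporter, with a stated time of 23 h; a higher number here means that more compound is needed for the effect, a lower number that less compound is needed:
- compound 1 `Cc1ccc(-c2nc3sccn3c2/C=N/OCc2ccc(Cl)c(Cl)c2)cc1`: 490 nM
- compound 2 `C(=N/OCc1ccccc1)\c1c(-c2ccc3ccccc3c2)nc2occn12`: 840 nM
- compound 3 `Clc1ccc(CO/N=C/c2c(-c3ccc4ccccc4c3)nc3sccn23)cc1Cl`: 380 nM

Compound 2 sits at the high end of these three numbers; its gap to compound 1 is within the scatter, its gap to compound 3 beyond it. Compound 4 `CC(C)(C)c1ccc(CO/N=C/c2c(-c3ccc4ccccc4c3)nc3occn23)cc1` differs from compound 2 by tert-butyl in place of hydrogen on an aromatic carbon. Among the compounds with values here, the only measured step, a 1.3-fold lower number from compound 1 to compound 3 (0.11 log units; within the scatter), concerns the other aryl group and is within the scatter; no measured step alters the benzyl ring. No shift beyond the scatter is therefore expected, and the step from compound 2 to compound 4 is estimated as a 1.2-fold lower number from compound 2 to compound 4 (0.08 log units; within the scatter). Compound 4 is expected to give 700 nM in this assay, in a range from 250 nM to 2000 nM.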

Compound 4, half-maximal effective concentration: 7900 nM
Beside the measured number, compound 4's estimate is 11-fold (1.05 log units) below it; measured number outside the range, above it.
By their numbers in this assay, from the lowest: compounds 3, 1 and 2 (each within the scatter of the next, the first and the last beyond it); then compound 4.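

In this assay, tert-butyl in place of hydrogen, para to a large group, gives a 9.4-fold higher number from compound 2 to compound 4 (0.97 log units; beyond the scatter). This position on the six-membered aromatic ring therefore responds to substitution, whereas the aryl change gave only a 1.3-fold lower number from compound 1 to compound 3 (0.11 log units; within the scatter). No measurement shown here explains the rise in the number.
On these data alone, whether the rise is specific to tert-butyl remains open; a methyl group, an amine or a carboxylic acid at the same place would test this. Also open, as far as these compounds go, is whether tert-butyl has the same effect on the core of compound 1.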